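Swapping 2-fluorophenyl for thiophen-2-yl on a shared core

The compounds below may be only part of what the source reports. "The series", "measured", "known", "first", "only" and "open" are said of these compounds alone.

Of the compounds shown here, three built on one core have been measured in a functional assay on NCI-H522 cells (Homo sapiens) for inhibition, read by sulforhodamine B assay, with a stated time of 48 h, tested at 10 uM; a higher number here means more inhibition at the concentration tested (going by the name of the read-out), a lower number less inhibition. Compound 1 `COc1ccc(-c2cn3ccnc3c(-c3ccc4ncn(C5CCCCC5)c4c3)n2)cc1` gives -20.9%. Compound 2 `c1ccc2c(-c3cn4ccnc4c(-c4ccc5ncn(C6CCCCC6)c5c4)n3)cccc2c1` gives 19.3%, and compound 3 `Fc1ccccc1-c1cn2ccnc2c(-c2ccc3ncn(C4CCCCC4)c3c2)n1` gives 17.8%. Compound 3 therefore stands second highest of the three numbers: its nearest neighbour is compound 2, within the usual scatter, while compound 1 lies far lower, beyond it.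

Compound 4 `c1csc(-c2cn3ccnc3c(-c3ccc4ncn(C5CCCCC5)c4c3)n2)c1` differs from compound 3 in one place: thiophen-2-yl in place of 2-fluorophenyl on an aromatic carbon. For the measured compounds named here, two measured steps bear on this change, as both alter the same group on the core: the large step of a number 38.7 percentage points higher from compound 1 to compound 3 (beyond the scatter) and the small step of a number 1.5 percentage points lower from compound 2 to compound 3 (within the scatter). Going by the values given here, no thiophene-bearing analogue has been measured, so the coming step is uncertain. Since a naphthalen-1-yl and a 2-fluorophenyl group sit within scatter of each other while the 4-methoxyphenyl compound falls well below, a modest downward step is expected, a number 9.8 percentage points lower from compound 3 to compound 4 (within the scatter). Compound 4 is thus expected to give about 8%, in a range from -20% to 32%.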

Compound 4, a percentage reported as inhibition, at one concentration (the size of the read-out at that concentration, not a potency): 13.2%
Compound 4: the middle estimate sits 5.2 percentage points below what was measured; measured number inside the range.
By their numbers in this assay, from the lowest: compound 1; then compounds 4, 3 and 2 (each within the scatter of the next).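

In this assay, replacing 2-fluorophenyl with thiophen-2-yl at this position, on the six-membered aromatic ring with 2 nitrogen, gives a number 4.6 percentage points lower from compound 3 to compound 4 (within the scatter), and replacing naphthalen-1-yl with it gives a number 6.1 percentage points lower from compound 2 to compound 4 (within the scatter), so a five-membered aromatic ring with a sulfur atom reads alongside both larger groups. Replacing 4-methoxyphenyl with thiophen-2-yl gives a number 34.1 percentage points higher from compound 1 to compound 4 (beyond the scatter), which leaves compound 1 set apart from three different aromatic groups rather than two. No measured evidence is available to explain these readings.

The compounds shown leave open whether the low number of compound 1 comes from the methoxy group itself or from where it sits on the phenyl ring. Going by these compounds, every group compared here is aromatic, so how an aliphatic amine, a carboxylic acid or a morpholine would read at this position remains unknown.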